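Swapping a Halogen on the Triazole Aryl Tail

This account rests on a few compounds, and the source may have more. Where it says the series, first, only, none or still open, it means among the compounds named here.

Compound 1 `C=C1C(=O)[C@]23C[C@@]1(O)CC[C@H]2c1ccc(OS(=O)(=O)c2ccc(C)cc2)c(C)c1[C@@H]3Cn1cc(-c2ccccn2)nn1` gives 320 nM in a functional assay on MCF7 cells (Homo sapiens) for cytotoxicity, read by MTT assay, with a stated time of 4 days; a lower number here means a stronger inhibitor, a higher number a weaker inhibitor. Compound 2 `C=C1C(=O)[C@]23C[C@@]1(O)CC[C@H]2c1ccc(OS(=O)(=O)c2ccc(C)cc2)c(C)c1[C@@H]3Cn1cc(-c2ccc(Br)cc2)nn1` gives 250 nM in this assay.

For the measured compounds named here, compound 2 holds the smaller of these two numbers, yet the single step, a 1.3-fold lower number from compound 1 to compound 2 (0.11 log units; within the scatter), lies within the scatter, so the two compounds are not separated. Compound 3 `C=C1C(=O)[C@]23C[C@@]1(O)CC[C@H]2c1ccc(OS(=O)(=O)c2ccc(C)cc2)c(C)c1[C@@H]3Cn1cc(-c2ccc(Cl)cc2)nn1` differs from compound 2 by chloro in place of bromo on an aromatic carbon. Going by the values given here, no measured step exchanges one halogen for another; the only step available, a 1.3-fold lower number from compound 1 to compound 2 (0.11 log units; within the scatter), replaced a whole aromatic group and still stayed within the scatter. The expected step is therefore a 1.1-fold higher number from compound 2 to compound 3 (0.05 log units; within the scatter), nothing beyond the scatter. Compound 3 is estimated at 280 nM, between 140 nM and 560 nM.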

Compound 3, half-maximal inhibitory concentration: 1440 nM
Beside the measured number, compound 3's estimate is 5.1-fold (0.71 log units) below it; measured number above the stated range.
By their numbers in this assay, from the lowest: compounds 2 and 1 (each within the scatter of the next); then compound 3.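

At this place on the ring, exchanging one halogen for another is not a neutral change: in this assay, chloro in place of bromo gives a 5.8-fold higher number from compound 2 to compound 3 (0.76 log units; beyond the scatter). The 4-chlorophenyl tail also stands apart from the pyridin-2-yl tail, with a 4.5-fold higher number from compound 1 to compound 3 (0.65 log units; beyond the scatter), whereas the 4-bromophenyl tail did not, so the tail's effect here depends on which halogen it carries. No available data explain the gap between bromo and chloro. On these data alone, whether a fluoro or iodo group would track bromo or chloro remains open, and so does the outcome with a methoxy group or an amine at this place.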